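A few compounds are considered here, and "the series" means these few. Any claim that something is new, unique, unknown or untested is made for them only; others in the source may bear on it.

Compound 1 `Cc1oc2c3c(ccc2c(=O)c1C)OC[C@H]1[C@@H]3C2=C(CCCC2=O)OC1(C)C` is tested in a functional assay on A549 cells (Homo sapiens) for antiproliferative activity, read by MTT assay, with a stated time of 48 h; a higher number here means a weaker inhibitor, a lower number a stronger inhibitor. In this assay compound 1 gives only a limit, > 100000 nM. Compound 2 `Cc1coc2c3c(ccc2c1=O)OC[C@H]1[C@@H]3C2=C(CCCC2=O)OC1(C)C` carries hydrogen in place of methyl on an aromatic carbon. In this assay compound 2 likewise gives only a limit, > 100000 nM. The step from compound 1 to compound 2 is accordingly a step that the two limits leave unreadable from compound 1 to compound 2, since both values sit at the limit of > 100000 nM in this assay, at which 2 of the 2 values shown sit. Compound 3 `Cc1oc2c3c(ccc2c(=O)c1-c1ccccc1)OC[C@H]1[C@@H]3C2=C(CCCC2=O)OC1(C)C` differs from compound 1 by phenyl in place of methyl on an aromatic carbon. Within the data shown here, no measured step bears directly on this change; the one step known, from compound 1 to compound 2, is unreadable, and nothing among the measured pairs ties a phenyl in place of methyl to a gain or a loss in this assay. With both measured values resting at the limit of > 100000 nM in this assay, at which 2 of the 2 values shown sit, compound 3 is expected to sit near that limit as well, and the step of a number no higher from compound 1 to compound 3 (the limit leaves the size open) is estimated to remain within the scatter of a pair that itself could not be read. Compound 3 is therefore estimated at 100000 nM in this assay, with a range from 30000 nM to 300000 nM.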

Compound 3, half-maximal inhibitory concentration: > 100000 nM
Compound 3: only a limit was reported; the forecaster's own chance of this, stated with the estimate: 80%; the middle value lies on the limit itself.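

In this assay, among these compounds, compound 3 also gives only a limit, > 100000 nM, so no step from compound 1 to compound 3 can be read, and compounds 1, 2 and 3 share one ceiling: the limit of > 100000 nM in this assay, at which 3 of the 3 values shown sit. The compounds shown leave open whether hydrogen or phenyl in place of methyl changes activity at all, and in which direction.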